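The source may report more compounds than this note shows. Statements on the series, on what has been measured and on what is new or still open speak of the compounds shown alone.

In a functional assay for inhibition, with Rattus norvegicus as the target, at pH 7.35 (on this read-out higher numbers stand for weaker inhibition and lower numbers for stronger inhibition), three compounds have been measured so far. Compound 1 `CCC(NC(=O)C(CC(C)C)NC(=O)OCc1ccccc1)C(=O)C(=O)OC` gives 280000 nM in this assay, the highest number of the three, which means the weakest inhibition. Compound 2 `CCC(=O)C(=O)[C@H](CC)NC(=O)[C@H](CC(C)C)NC(=O)[C@H](CC(C)C)NC(=O)OCc1ccccc1` gives 40000 nM, and compound 3 `CCOC(=O)C(=O)[C@H](CC)NC(=O)[C@H](CC(C)C)NC(=O)[C@H](CC(C)C)NC(=O)c1ccc2ccccc2c1` gives 78000 nM. Both of these lie below compound 1 by gaps that are beyond the usual scatter; compound 3 sits nearest to compound 1 and compound 2 furthest from it. Compounds 2 and 3 carry a longer chain of building blocks than compound 1, so no single-change comparison can be drawn among the measured compounds.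

Compound 4 `CCC(NC(=O)C(CC(C)C)NC(=O)OCc1ccccc1)C(=O)C(=O)O` has not yet been measured. It differs from compound 1 in one place only: hydrogen in place of methyl on an oxygen next to a carbonyl group. Among the measured compounds shown here, no measured pair shows this change, so its effect on this assay can only be guessed. The expectation is a modest step, if any, most likely towards a somewhat higher number, and quite possibly none beyond the scatter, so the step from compound 1 to compound 4 is estimated as a 1.4-fold higher number from compound 1 to compound 4 (0.15 log units; within the scatter). On that basis compound 4 is expected to give about 400000 nM in this assay, within a range from 100000 nM to 1500000 nM.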

Compound 4, half-maximal inhibitory concentration: 100000 nM
Estimate against measurement, compound 4: 4.0-fold (0.60 log units) above; measured number inside the range.
By their numbers in this assay, from the lowest: compounds 2, 3 and 4 (each within the scatter of the next, the first and the last beyond it); then compound 1.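

In this assay, among the compounds shown here, the change from methoxy to hydroxy, which turns the methoxycarbonyl group into a carboxy group, provides the first single-change comparison in this set, and it gives a 2.8-fold lower number from compound 1 to compound 4 (0.45 log units; beyond the scatter). The step is modest but beyond the usual scatter, so this position on the shared core does respond to a small edit, and here the response is stronger inhibition on this read-out. The methyl group on this oxygen is therefore not required for the inhibition seen in this pair, although nothing measured here explains why removing that one carbon shifts the number.

On these data alone, this is a single pair on one short backbone, so it remains open whether the same change would produce a step of similar size or direction on the longer chains of building blocks. It also leaves open how a benzyl group on this oxygen, or an amide in place of the ester or carboxy group, would compare with the methyl group and the hydrogen at this position.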